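The source may hold more compounds than are shown below. What is called first, only, known or untested is meant among the compounds shown, and "the series" means these compounds.

Measured in a physicochemical assay for lipophilicity; on this read-out higher numbers stand for higher lipophilicity and lower numbers for lower lipophilicity:
Compound 1, `COc1cccc(CNCc2c(-c3nnc(SC(C)C)n3-c3ccccc3)n(C)c3ccccc23)c1`, gives 6.27.
Compound 2, `COc1ccc(CNCc2c(-c3nnc(SC(C)C)n3-c3ccccc3)n(C)c3ccc(F)cc23)cc1`, gives 6.42.

Compound 1 holds the lower of the two numbers shown; the nearest is compound 2, whose value sits higher by an amount within the usual scatter, so the two cannot be told apart on this read-out. Compound 3, `CC(C)Sc1nnc(-c2c(CNCCN3CCCC3)c3ccccc3n2C)n1-c1ccccc1`, has not yet been measured in this assay. It differs from compound 1 in one place: (pyrrolidin-1-yl)methyl in place of 3-methoxyphenyl on a saturated chain carbon bound to an amine nitrogen. Cut one bond further out, the same change reads 3-methoxybenzyl to 2-(pyrrolidin-1-yl)ethyl on the amine. Among the measured compounds shown here, no measured pair in this set shows a step of this kind, so the expectation rests on the structural change alone. Compound 3 is expected to come out clearly lower than compound 1 in this assay, by a step of a number 1.77 log units lower from compound 1 to compound 3 (beyond the scatter), well beyond the scatter. The estimate for compound 3 is 4.5, with a range from 3.8 to 5.3.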

Compound 3, partition coefficient: 4.83
Compound 3: the middle estimate sits 0.33 log units below what was measured; low and high end bracket the measured number.
By their numbers in this assay, from the lowest: compound 3; then compounds 1 and 2 (each within the scatter of the next).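

In this assay, among the compounds shown here, exchanging 3-methoxybenzyl for 2-(pyrrolidin-1-yl)ethyl on the amine gives a number 1.44 log units lower from compound 1 to compound 3 (beyond the scatter), a large step and the first comparison in this set between compounds that differ in one place. It shows that the read-out responds clearly at this position, a saturated chain carbon bound to an amine nitrogen, when the 3-methoxyphenyl group leaves and the (pyrrolidin-1-yl)methyl group enters. No accompanying measurement indicates which part of this change accounts for the step.

Going by these compounds, the exchange alters the ring, the methoxy group and the chain together, so their separate contributions remain open. Also open, on these data alone, is whether a plain benzyl, a 2-(piperidin-1-yl)ethyl or a 2-(morpholin-4-yl)ethyl group on the same amine would fall nearer compound 1 or compound 3.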